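Selenium-bridged diacyl isoselenoureas: benzyl to methyl on two cores

The compounds below may be only part of what the source reports. "The series", "measured", "known", "first", "only" and "open" are said of these compounds alone.

Four compounds built on a selenium-bridged diacylisoselenourea frame are considered, and their growth inhibition is measured in a functional assay on HepG2 cells (Homo sapiens) for cytotoxicity, read by MTT assay, with a stated time of 72 h; a higher number here means a weaker inhibitor of growth, a lower number a stronger inhibitor of growth. Compound 1 `O=C(/N=C(/NC(=O)c1cc(-c2ccccc2)nc2ccccc12)[Se]Cc1ccccc1)c1cc(-c2ccccc2)nc2ccccc12` gives 25800 nM. Compound 2 `C[Se]/C(=N\C(=O)c1cc(-c2ccccc2)nc2ccccc12)NC(=O)c1cc(-c2ccccc2)nc2ccccc12` differs from compound 1 in one place, (hydrogen in place of phenyl on a saturated chain carbon bound to a selenium atom), and in this assay compound 2 gives 4540 nM. The step of a 5.7-fold lower number from compound 1 to compound 2 (0.75 log units; beyond the scatter) is therefore a clear move toward stronger inhibition of growth.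

Compound 3 `O=C(/N=C(/NC(=O)c1csc([N+](=O)[O-])c1)[Se]Cc1ccccc1)c1csc([N+](=O)[O-])c1` carries a different core; how its core differs from that of compound 1 is not broken down here. In this assay compound 3 gives 34100 nM, a number that lies within the scatter of the value of compound 1, so the two are not distinguished, while it stands clearly apart from compound 2.

Compound 4 `C[Se]/C(=N\C(=O)c1csc([N+](=O)[O-])c1)NC(=O)c1csc([N+](=O)[O-])c1` is not yet measured. It differs from compound 3 by hydrogen in place of phenyl on a saturated chain carbon bound to a selenium atom, the same change, at the same place, that leads from compound 1 to compound 2. Resting on the single precedent a 5.7-fold lower number from compound 1 to compound 2 (0.75 log units; beyond the scatter), the step from compound 3 to compound 4 is expected to be of comparable size, a 5.7-fold lower number from compound 3 to compound 4 (0.75 log units; beyond the scatter). Compound 4 is accordingly estimated at 6000 nM in this assay, with a plausible range from 2500 nM to 15000 nM. This expectation rests on one pair only, and the core of compound 3 may answer the change differently from that of compound 1.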

Compound 4, concentration for 50% growth inhibition: 620 nM
For compound 4 the middle estimate is 9.7-fold (0.99 log units) above the measured one; measured number outside the range, below it.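

In this assay the change from benzyl to methyl gives a 55-fold lower number from compound 3 to compound 4 (1.74 log units; beyond the scatter) and so repeats, on the core of compound 3, the direction already seen on the core of compound 1. Going by these compounds alone, with only two cores, this shows a shared direction for these two pairs, but it does not show why the step is larger on one core or how any further core would respond. The size of the step does not carry over from one core to the other, so a step measured on one core cannot simply be applied to the other: the same change on two cores in this assay, a 5.7-fold lower number (0.75 log units; beyond the scatter) from compound 1 to compound 2 and a 55-fold lower number (1.74 log units; beyond the scatter) from compound 3 to compound 4, 9.7-fold (0.99 log units) apart, beyond the scatter of two such steps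

The compounds shown leave open whether groups other than benzyl and methyl in this place, such as an ethyl group, a longer chain, or a chain ending in an amine or a carboxylic acid, would follow the same direction. They also leave open which part of the core of compound 3 goes with the larger step, for instance whether putting a hydrogen or an amine in place of its nitro group would bring the step closer to the one seen on the core of compound 1.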